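Swapping the sulfonyl aryl group of compound 3

This account rests on a few compounds, and the source may have more. Where it says the series, first, only, none or still open, it means among the compounds named here.

Measured so far, in a functional assay on HL-60 cells (Homo sapiens) for inhibition, read by CCK-8 assay, with a stated time of 48 h, tested at 20 uM; on this read-out higher numbers stand for more inhibition of growth at the one concentration tested and lower numbers for less inhibition of growth:
compound 1, `Cc1ccc(S(=O)(=O)Oc2ccccc2/C=C(\C#N)C(=O)Nc2nnc(C)s2)cc1`, gives 78%
compound 2, `COc1ccc(Cc2nnc(NC(=O)/C(C#N)=C/c3ccccc3OS(=O)(=O)c3ccc(C)cc3)s2)cc1`, gives 25%
compound 3, `Cc1ccc(S(=O)(=O)Oc2ccccc2/C=C(\C#N)C(=O)Nc2nnc(Cc3ccccc3)s2)cc1`, gives 16%

Compound 3 has the lowest of the three numbers. Compound 2 is nearest, with a number 9 percentage points lower from compound 2 to compound 3 (within the scatter); compound 1 is furthest, with a number 62 percentage points lower from compound 1 to compound 3 (beyond the scatter).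

Compound 4, `N#C/C(=C\c1ccccc1OS(=O)(=O)c1ccccc1[N+](=O)[O-])C(=O)Nc1nnc(Cc2ccccc2)s1`, differs from compound 3 in one place: 2-nitrophenyl in place of 4-methylphenyl on a sulfonyl sulfur. Going by the values given here, no measured step touches that place. The two large steps, a number 53 percentage points lower from compound 1 to compound 2 (beyond the scatter) and a number 62 percentage points lower from compound 1 to compound 3 (beyond the scatter), concern the group at the other end of the shared core, and the remaining step of a number 9 percentage points lower from compound 2 to compound 3 (within the scatter) also lies there. The data therefore give no ground for a change beyond the usual scatter in this assay, and a flat step is expected: a number 4 percentage points higher from compound 3 to compound 4 (within the scatter). Compound 4 is estimated at 20%, with a range from 5% to 45%.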

Compound 4, percent growth inhibition at one concentration: 12%
Compound 4: middle estimate off by 8 percentage points, on the high side; the measured number falls inside the stated range.
By their numbers in this assay, from the lowest: compounds 4, 3 and 2 (each within the scatter of the next, the first and the last beyond it); then compound 1.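

Going by these compounds alone, the group on the sulfonyl sulfur is varied here for the first time: in this assay, 2-nitrophenyl in place of 4-methylphenyl gives a number 4 percentage points lower from compound 3 to compound 4 (within the scatter), so no change can be read from this swap. The result holds only with the benzyl-type end group of compound 3, where inhibition is already low. Nothing available explains the result.

Still open, from the compounds shown here alone, is whether the same swap would stay flat on compound 1, with its far higher number. Also open, going by these compounds, is how an aryl ring carrying an amine or a carboxylic acid would read on the sulfonyl sulfur.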